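Swapping the triazole aryl group on an inactive scaffold

This account rests on a few compounds, and the source may have more. Where it says the series, first, only, none or still open, it means among the compounds named here.

Compound 1 `C=C1C[C@]23C[C@@]1(O)CC[C@H]2c1cc(Br)c(O)c(C)c1[C@@H]3Cn1cc(-c2ccccn2)nn1`: in a functional assay on SMMC-7721 cells (Homo sapiens) for cytotoxicity, read by MTT assay, with a stated time of 4 days (on this read-out lower numbers stand for stronger inhibition and higher numbers for weaker inhibition), compound 1 reaches only the assay limit, > 20000 nM.
Compound 2 `Cc1c(O)ccc2c1[C@H](Cn1cc(-c3ccccc3)nn1)[C@@]13CC(=O)[C@@](C)(CC[C@@H]21)C3`: in this assay compound 2 also stops at the assay limit, > 20000 nM.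
Compound 3 `C=C1C[C@]23C[C@@]1(O)CC[C@H]2c1ccc(OS(=O)(=O)c2ccc(C)cc2)c(C)c1[C@@H]3Cn1cc(-c2ccc(C)cc2)nn1`: in this assay compound 3 likewise gives the assay limit, > 20000 nM.

Compound 1 therefore stands nowhere in particular on these numbers: its value is a limit, not a measurement, and the same holds for the two other compounds (the limit of > 20000 nM in this assay, at which 3 of the 3 values shown sit). Within the data shown here, no step between measured compounds can be sized, so nothing orders compound 1, compound 2 and compound 3 against one another.

Compound 4 `C=C1C[C@]23C[C@@]1(O)CC[C@H]2c1cc(Br)c(O)c(C)c1[C@@H]3Cn1cc(-c2ccc(Cl)cc2)nn1` is the next compound, differing from compound 1 in one place: 4-chlorophenyl in place of pyridin-2-yl on an aromatic carbon. With every measured compound sitting at the limit (the limit of > 20000 nM in this assay, at which 3 of the 3 values shown sit), the expected step in this assay is none beyond the scatter, and the most likely outcome is that compound 4 again returns only a limit. The expected step is a step that the limit leaves unreadable from compound 1 to compound 4. Compound 4 is estimated at 25000 nM, with a range from 8000 nM to 60000 nM.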

Compound 4, half-maximal inhibitory concentration: 19100 nM
Estimate against measurement, compound 4: 1.3-fold (0.12 log units) above, within the range that was stated.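

In this assay compound 4 gives a true measured number, 19100 nM, which shows that an aryl group in this place on the five-membered aromatic ring with 3 nitrogen can yield a reading on this scaffold. Compound 1 remains a limit, > 20000 nM, and not a number. Putting 4-chlorophenyl in place of pyridin-2-yl gives an at least 1.0-fold lower number from compound 1 to compound 4 (0.01 log units; that floor lies within the scatter), so this change cannot be called an improvement, and compound 4 is the only reading among compounds otherwise held at the limit: the limit of > 20000 nM in this assay, at which 3 of the 4 values shown sit.

As far as these compounds go, the true size of this step stays unknown, as does whether the chlorine or the carbon-only ring matters more. Also open, from the compounds shown here alone, is whether a ring carrying an amine or a carboxylic acid in this same place on the core of compound 1 would move the number further.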